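Adding a Thiophene Ring to a Weakly Active Scaffold

This account rests on a few compounds, and the source may have more. Where it says the series, first, only, none or still open, it means among the compounds named here.

Compound 1 `c1coc(-c2ccnc(-c3cccs3)c2)c1` was tested in a functional assay on SK-MEL-2 cells (Homo sapiens) for antiproliferative activity (a lower number here means that less compound is needed, a higher number that more compound is needed for the effect), where compound 1 gives 118000 nM. Two related compounds were measured alongside it. Compound 2 `C(=C/c1cccs1)\c1cc(-c2cccs2)cc(-c2cccs2)n1` gives 118000 nM, and compound 3 `c1ccc(-c2cc(-c3ccco3)ccn2)nc1` gives 118000 nM. On these numbers compound 1 stands level with both companions: its value agrees with that of compound 2 at the digits shown, and likewise with that of compound 3, so none of the three is set apart beyond the usual scatter.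

Compound 4 `c1coc(-c2cc(-c3cccs3)nc(-c3cccs3)c2)c1` has not yet been measured. It differs from compound 1 in one place: thiophen-2-yl in place of hydrogen on an aromatic carbon. For the measured compounds named here, no pair of measured compounds here differs by exactly one change, so there is no measured step that tells the size of this one. What the measured values do show is that compound 2, whose core likewise carries thiophen-2-yl groups, gives a value that agrees with that of compound 1. The expected step of no change at the digits printed from compound 1 to compound 4 (within the scatter) in this assay therefore means no change beyond the scatter. Compound 4 is accordingly expected to give 118000 nM, with a range from 45000 nM to 250000 nM.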

Compound 4, half-maximal effective concentration: 118000 nM
Compound 4: the middle estimate sits on the measured number at the digits printed; the range from low to high includes it.
By their numbers in this assay, from the lowest: compounds 1, 2, 3 and 4 (each within the scatter of the next).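

In this assay the measured step is no change at the digits printed from compound 1 to compound 4 (within the scatter), so placing thiophen-2-yl in place of hydrogen on this aromatic carbon, next to the ring nitrogen, gives no shift that can be told apart from the scatter. For the compounds shown here, this is the first direct comparison in the set, as the earlier compounds differ from one another in more than one place and could only be set side by side. It shows that, at this position and in this assay, adding a five-membered aromatic ring of 5 heavy atoms to the core of compound 1 does not move the number beyond the scatter. Nothing measured here explains why the value holds steady.

As far as these compounds go, this single step covers one group at one position, so it remains open whether an amine, a carboxylic acid or a longer chain on the same carbon would give a different number. Also open is whether any change to this core can lower the value, as all four compounds shown print the same number.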